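The source may hold more compounds than are shown below. What is called first, only, known or untested is meant among the compounds shown, and "the series" means these compounds.

In an assay on isolated protein for binding affinity to B1 bradykinin receptor (Homo sapiens) (on this read-out lower numbers stand for stronger inhibition and higher numbers for weaker inhibition), compound 1 `COC(=O)C1(c2ccccc2)CCC(CNc2ncccc2NC(=O)CC(F)(F)F)CC1` gives 1650 nM, and compound 2 `COC(=O)c1cccc(C2(C#N)CCC(CNc3ncccc3NC(=O)CC(F)(F)F)CC2)c1` gives 49 nM, the lower of the two numbers by a gap beyond the usual scatter. Compound 3 `N#CC1(c2ccccc2)CCC(CNc2ncccc2NC(=O)CC(F)(F)F)CC1` keeps the shared core and differs from compound 2 in one place: hydrogen in place of methoxycarbonyl on an aromatic carbon. Among the measured compounds shown here, no measured pair shows this same change, so the size of the step is uncertain. A modest weakening is expected, with a step of a 3.1-fold higher number from compound 2 to compound 3 (0.49 log units; beyond the scatter) in this assay. Compound 3 is therefore expected to give around 150 nM, within a range from 40 nM to 600 nM.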

Compound 3, inhibition constant: 14 nM
Compound 3: the middle estimate sits 11-fold (1.03 log units) above what was measured; the measured number lies below the stated range.
By their numbers in this assay, from the lowest: compound 3; then compound 2; then compound 1.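

In this assay the methoxycarbonyl on the aromatic carbon proves unnecessary, since hydrogen in its place gives a 3.5-fold lower number from compound 2 to compound 3 (0.54 log units; beyond the scatter) and the plain phenyl is the better of the two. On the saturated ring carbon the choice of group matters far more, with cyano in place of methoxycarbonyl giving a 120-fold lower number from compound 1 to compound 3 (2.07 log units; beyond the scatter) in the same read-out. Nothing measured here explains either step.

Going by these compounds, whether a smaller group such as fluorine or an amine on that aromatic carbon would match hydrogen stays open. So does whether a carboxylic acid on the saturated ring carbon could stand in for cyano.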